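This account rests on a few compounds, and the source may have more. Where it says the series, first, only, none or still open, it means among the compounds named here.

Of the compounds shown here, three sharing one core have been measured in a functional assay on MCF7 cells (Homo sapiens) for inhibition, read by fluorescence, with a stated time of 72 h; on this read-out lower numbers stand for stronger inhibition and higher numbers for weaker inhibition: compound 1 `CC(C)[C@H](N)COc1nc(NC(=N)N)c2ncn(C(C)C)c2n1` gives 3400 nM and compound 2 `CC(C)[C@@H](CO)Nc1nc(NC(=N)N)c2ncn(C(C)C)c2n1` gives 2100 nM while compound 3 `CC(C)n1cnc2c(NC(=N)N)nc(NC3CC3)nc21` gives 5400 nM as the highest of the three numbers. That position is only partly firm. The measured 1.6-fold higher number from compound 1 to compound 3 (0.20 log units; within the scatter) stays within the scatter, whereas a 2.6-fold higher number from compound 2 to compound 3 (0.41 log units; beyond the scatter) lies beyond it, though modestly.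

Compound 4 `CC(C)n1cnc2c(NC(=N)N)nc(OC[C@H]3CCCN3)nc21` has not yet been measured. It differs from compound 3 by (pyrrolidin-2-yl)methoxy in place of cyclopropylamino on an aromatic carbon on an aromatic carbon, with (pyrrolidin-2-yl)methoxy in place of cyclopropylamino.

The closest guide is compound 1, which carries 2-amino-3-methylbutoxy at the same place, and its a 1.6-fold higher number from compound 1 to compound 3 (0.20 log units; within the scatter) runs opposite to the change now in question. The other change at this place, a 1.6-fold lower number from compound 1 to compound 2 (0.21 log units; within the scatter) also within the scatter, adds no sign of a large effect. None of these steps is large, so only a small move toward a lower number is expected, and no move beyond the scatter. The expected change is a 1.5-fold lower number from compound 3 to compound 4 (0.19 log units; within the scatter) on this estimate. The estimated value for compound 4 is 3500 nM with an expected range from 1500 nM to 8000 nM around that figure.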

Compound 4, half-maximal inhibitory concentration: > 100000 nM
Compound 4 ended at the assay's limit (the forecaster's own chance of this, stated with the estimate: 3%); middle value at least 28-fold (1.45 log units) from the limit.
By their numbers in this assay, from the lowest: compounds 2, 1 and 3 (each within the scatter of the next, the first and the last beyond it). At a limit, above all of these: compound 4.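

Compound 4 gives > 100000 nM in this assay, which is a limit of the assay and not a number. At this aromatic carbon between two ring nitrogen atoms, the earlier exchanges among 2-amino-3-methylbutoxy, (1-(hydroxymethyl)-2-methylpropyl)amino and cyclopropylamino gave steps that were within the scatter or only modest, whereas (pyrrolidin-2-yl)methoxy gives an at least 18-fold higher number from compound 3 to compound 4 (1.26 log units; beyond the scatter) and an at least 47-fold higher number from compound 2 to compound 4 (1.67 log units; beyond the scatter), so this place is far less forgiving than those compounds suggested. The oxygen-linked chain is kept in the remaining comparison, where pyrrolidin-2-yl replaces 1-amino-2-methylpropyl and the result is an at least 29-fold higher number from compound 1 to compound 4 (1.46 log units; beyond the scatter), so the oxygen link by itself does not go with the loss and the sharp change follows the end of the chain.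

The compounds shown leave open how far the number truly lies past the limit, and whether the ring or the defined stereocentre of the (pyrrolidin-2-yl)methoxy group is what matters. The opposite stereocentre, a piperidin-2-ylmethoxy group or an open-chain secondary amine on the same oxygen link would separate these possibilities.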